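The compounds below may be only part of what the source reports. "The series", "measured", "known", "first", "only" and "open" are said of these compounds alone.

Measured so far:
compound 1, `CNCC(=O)Nc1cc(OC)ccc1C(=O)c1ccc(OC)c2c1OC(C)(C)C=C2`, 740 nM;
compound 2, `COc1ccc(C(=O)c2ccc(OC)c3c2OC(C)(C)C=C3)c(NC(=O)CN(C)C)c1`, 1590 nM;
compound 3, `C=C(c1ccc(OC)cc1NC(=O)CN)c1ccc(OC)c2c1OC(C)(C)C=C2`, 190 nM.

All three were tested in a functional assay on HCT-8 cells (Homo sapiens) for antiproliferative activity, read by MTT assay, with a stated time of 48 h; a higher number here means a weaker inhibitor, a lower number a stronger inhibitor. Compound 1 differs from compound 2 by methyl in place of hydrogen on an amine nitrogen, and that step gave a 2.1-fold higher number from compound 1 to compound 2 (0.33 log units; beyond the scatter). Compound 3 has the lowest number of the three, and how its core differs from that of compound 1 is not broken down here. Compound 4, `C=C(c1ccc(OC)cc1NC(=O)CNC)c1ccc(OC)c2c1OC(C)(C)C=C2`, has not been measured; it differs from compound 3 by methyl in place of hydrogen on an amine nitrogen. This is the same kind of change as the earlier one, though the place is not identical: in the first case the amine nitrogen carries two saturated chain carbons, here only one. Resting on the earlier step from compound 1 to compound 2, the author expects a rise of similar size, a 2.1-fold higher number from compound 3 to compound 4 (0.32 log units; beyond the scatter). Compound 4 is therefore estimated at 400 nM, with a range of 200 nM to 850 nM.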

Compound 4, half-maximal inhibitory concentration: 320 nM
Estimate against measurement, compound 4: 1.3-fold (0.10 log units) above; the range from low to high includes it.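

In this assay, methyl in place of hydrogen on the amine nitrogen gave a 1.7-fold higher number from compound 3 to compound 4 (0.23 log units; within the scatter). Set beside the earlier step, the change shows no difference in size between the two cores: the same change on two cores in this assay, a 2.1-fold higher number (0.33 log units; beyond the scatter) from compound 1 to compound 2 and a 1.7-fold higher number (0.23 log units; within the scatter) from compound 3 to compound 4, 1.3-fold (0.11 log units) apart, within the scatter of two such steps. Going by these compounds alone, this is a match across only two pairs in one assay, so it does not show that the step would hold on any other core, and the new step taken alone cannot be told apart from the scatter.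

The compounds shown leave open how a dimethylamino group would behave on the core of compound 3. They also leave open how an ethyl group or a longer chain on that amine nitrogen would compare with methyl on either core.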